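The source may hold more compounds than are shown below. What is called first, only, known or untested is meant among the compounds shown, and "the series" means these compounds.

Series: three measured analogues and one open position. In a functional assay on COLO 205 cells (Homo sapiens) for inhibition, read by sulforhodamine B assay, tested at 100 uM (a higher number here means more inhibition of growth at the concentration tested, a lower number less inhibition of growth), compound 1 `COc1ccc(C2CC(c3ccc(OCc4cn(Cc5ccc([N+](=O)[O-])cc5)nn4)cc3)=NN2C(C)=O)cc1` gives 37%. Compound 2 `COc1cc(C2CC(c3ccccc3)=NN2C(C)=O)ccc1OCc1cn(Cc2ccc([N+](=O)[O-])cc2)nn1` gives 11% in this assay. Compound 3 `COc1cc(C2CC(c3cc(OC)c(OC)c(OC)c3)=NN2C(C)=O)ccc1OCc1cn(Cc2ccc([N+](=O)[O-])cc2)nn1` gives 99% in this assay, the highest of the three numbers, ahead of compound 1 and further ahead of compound 2, both gaps beyond the scatter. Within the data shown here, the only single-point step among the measured compounds is a number 88 percentage points higher from compound 2 to compound 3 (beyond the scatter). Compound 4 `COc1cc(C2CC(c3ccc(Cl)cc3)=NN2C(C)=O)ccc1OCc1cn(Cc2ccc([N+](=O)[O-])cc2)nn1` is not yet measured; it differs from compound 3 as 4-chlorophenyl in place of 3,4,5-trimethoxyphenyl on a carbon with a double bond to nitrogen. This change runs in the opposite sense to the measured step: it takes out the 3,4,5-trimethoxyphenyl and puts in 4-chlorophenyl rather than the bare phenyl of compound 2. Since the step from compound 2 to compound 3 was large, removing the 3,4,5-trimethoxyphenyl is expected to cost most of that gain; whether 4-chlorophenyl retains anything beyond the phenyl of compound 2 cannot be read from these compounds. For compound 4 a step of a number 69 percentage points lower from compound 3 to compound 4 (beyond the scatter) is therefore expected, placing compound 4 at an estimated 30% within 5% to 70%.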

Compound 4, percent growth inhibition at one concentration: 10%
For compound 4 the middle estimate is 20 percentage points above the measured one; the range from low to high includes it.
By their numbers in this assay, from the lowest: compounds 4 and 2 (each within the scatter of the next); then compound 1; then compound 3.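

In this assay the drop of a number 89 percentage points lower from compound 3 to compound 4 (beyond the scatter) shows that an aromatic ring on this carbon is not enough, since 4-chlorophenyl keeps the ring yet loses the gain seen with 3,4,5-trimethoxyphenyl. Chloro in place of hydrogen on the aromatic carbon gives a number 1 percentage points lower from compound 2 to compound 4 (within the scatter) and so adds nothing measurable over the bare phenyl. Among compound 2, compound 3 and compound 4, only the 3,4,5-trimethoxyphenyl stands apart at this position, and nothing here explains why.

Going by these compounds, whether all three methoxy groups are needed stays open, and 4-methoxyphenyl or 3,5-dimethoxyphenyl on this carbon would test that. Also open, on these data alone, is whether a different group, such as an amine on the phenyl ring, could match the 3,4,5-trimethoxyphenyl.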